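The source may report more compounds than this note shows. Statements on the series, on what has been measured and on what is new or still open speak of the compounds shown alone.

For the measured compounds named here, compound 1, `O=c1c2cc([N+](=O)[O-])ccc2n(CCCBr)n1Cc1ccccc1`, is the only compound with a plain number in an ADME assay on L929 cells (Mus musculus) for cytotoxicity, read by resazurin assay, with a stated time of 48 h; a lower number here means that less compound is tolerated, a higher number that more compound is tolerated: compound 1 gives 25200 nM. Compound 2, `NC(=O)CCCn1c2ccc([N+](=O)[O-])cc2c(=O)n1Cc1ccccc1`, gives only a limit in this assay, > 256000 nM. Going by the values given here, the step of an at least 10-fold higher number from compound 1 to compound 2 (1.00 log units; beyond the scatter) is the sole measured step; its size rests on (the limit of > 256000 nM in this assay, at which 1 of the 2 values shown sits), so the step is known only as a lower bound.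

Compound 3 is `O=C(c1ccccc1)n1c2ccc([N+](=O)[O-])cc2c(=O)n1Cc1ccccc1`; it differs from compound 1 by benzoyl in place of 3-bromopropyl on an aromatic nitrogen. The change shares with the measured step the loss of the bromo on the chain, but here the whole 3-bromopropyl leaves and a benzoyl enters on the aromatic nitrogen, a place not covered by any measured pair. Among the compounds with values here, on the one bearing step, a higher number is expected for compound 3, with a real chance of a limit. For compound 3 the estimate is 120000 nM, range 30000 nM to 400000 nM, meaning an expected step of a 4.8-fold higher number from compound 1 to compound 3 (0.68 log units; beyond the scatter).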

Compound 3, concentration lethal to 50% of the cells: 146000 nM
The estimate for compound 3 lay 1.2-fold (0.09 log units) below the measured number, within the range that was stated.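

In this assay, a change at the aromatic nitrogen that removes the whole 3-bromopropyl chain and brings in an aromatic ring gives a 5.8-fold higher number from compound 1 to compound 3 (0.76 log units; beyond the scatter). A higher number therefore no longer depends on a carbamoyl at the chain end, as compounds 2 and 3 both lie higher than compound 1 and neither goes against this within the three compounds. Compound 2 still gives only a limit, so an at least 1.7-fold lower number from compound 2 to compound 3 (0.24 log units; that floor lies within the scatter) is a floor and sets no firm order between 3-carbamoylpropyl and benzoyl: the limit of > 256000 nM in this assay, at which 1 of the 3 values shown sits.

Open, on these data alone, is whether the higher numbers follow the loss of the bromo or the entry of each new group, which a plain propyl chain, or a chain ending in an amine or a carboxylic acid, would help to separate. Also open, as far as these compounds go, is whether an acetyl on the aromatic nitrogen would behave as benzoyl does.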